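Oxime ester to oxime acid: notes on compound 4

The source may report more compounds than this note shows. Statements on the series, on what has been measured and on what is new or still open speak of the compounds shown alone.

In a functional assay on the whole organism for inhibition, with Rattus norvegicus as the target, read by paw edema, with stated times of 1 h and 3 h (a higher number here means that more compound is needed for the effect, a lower number that less compound is needed), compound 1 (`COC(=O)CO/N=C(\C)c1ccc(Cl)cc1`) gives 24 mg/kg. Compound 2 (`COC(=O)CO/N=C(\C)c1ccc(Br)cc1`) gives 14 mg/kg, and the gap between them stays within the scatter. Compound 3 (`C/C(=C\CC(=O)O)c1ccc(Cl)cc1`) gives 70 mg/kg, a higher number than that of compound 1 and beyond the scatter.

The next compound is compound 4 (`C/C(=N\OCCCC(=O)O)c1ccc(Cl)cc1`), reached by 2-carboxyethyl in place of methoxycarbonyl on a saturated chain carbon bound to an oxygen on an unsaturated carbon.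

Among the measured compounds shown here, the only measured step, a 1.7-fold lower number from compound 1 to compound 2 (0.23 log units; within the scatter), concerns bromo in place of chloro on an aromatic carbon, a different place, so it says little about this change. For the measured compounds named here, the nearest guide is compound 3 at 70 mg/kg, the only measured compound with a free carboxylic acid, although it also differs from compound 4 elsewhere. A moderate move towards a higher number is therefore expected, with low confidence. The expected step is a 1.9-fold higher number from compound 1 to compound 4 (0.27 log units; within the scatter). For compound 4 the estimate is 45 mg/kg, with an expected range of 18 mg/kg to 110 mg/kg.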

Compound 4, dose for half-maximal effect: 58 mg/kg
The estimate for compound 4 lay 1.3-fold (0.11 log units) below the measured number; measured number inside the range.
By their numbers in this assay, from the lowest: compounds 2 and 1 (each within the scatter of the next); then compounds 4 and 3 (each within the scatter of the next).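

Among the compounds shown here, at the saturated chain carbon bound to an oxygen on an unsaturated carbon, putting 2-carboxyethyl in place of methoxycarbonyl gives the first readable step at this position in this assay, a 2.4-fold higher number from compound 1 to compound 4 (0.38 log units; beyond the scatter), and it is modest in size. The exchange changes two things at once: the entering group is longer and carries a hydrogen-bond donor, whereas the leaving group carries none, and this single step cannot separate the two. Nothing measured here accounts for the step.

Still open, on these data alone, is whether the acid or the chain length sets the number, a question that the carboxylic acid on the shorter chain and the methyl ester on the longer chain would address. Also open, as far as these compounds go, are how a primary amide would read at this position and whether the bromo exchange carries over to the acid series.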